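The compounds below may be only part of what the source reports. "The series", "measured", "known", "first", "only" and "open" are said of these compounds alone.

Compound 3 `O=c1nc2ccccn2cc1Cc1ccccc1` is the unsubstituted member of the set. For the measured compounds named here, in a functional assay on SK-N-SH cells (Homo sapiens) for cytotoxicity, read by MTT assay, with a stated time of 24 h (a lower number here means a stronger inhibitor, a higher number a weaker inhibitor), compound 3 gives 95400 nM, the lowest of the three numbers so far, though both other compounds sit within the scatter of it. Compound 1 `O=c1nc2ccc(Br)cn2cc1Cc1ccccc1` carries a bromo on an aromatic carbon of the core, and in this assay compound 1 gives 137000 nM. Compound 2 `O=c1nc2ccccn2cc1Cc1ccc(Br)cc1` carries a bromo on an aromatic carbon of the other ring, and in this assay compound 2 gives 163000 nM. The measured steps are a 1.4-fold lower number from compound 1 to compound 3 (0.16 log units; within the scatter) and a 1.7-fold lower number from compound 2 to compound 3 (0.23 log units; within the scatter); both are within the scatter, so the bromo at either place leaves the number essentially unchanged.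

Compound 4 `Nc1cccn2cc(Cc3ccccc3)c(=O)nc12` is the next member, not yet measured in this assay. Its change from compound 3: amino in place of hydrogen on an aromatic carbon. Going by the values given here, no measured step concerns an amino group, so nothing bears directly on this change. Among the compounds with values here, the two steps known, both a hydrogen in place of bromo on an aromatic carbon and both within the scatter, show only that small changes on an aromatic carbon have so far moved nothing beyond the scatter. The step for compound 4 is therefore expected to be a 1.1-fold lower number from compound 3 to compound 4 (0.03 log units; within the scatter), within the scatter. Compound 4 is estimated at 90000 nM in this assay, with a range from 35000 nM to 250000 nM.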

Compound 4, half-maximal inhibitory concentration: 116000 nM
For compound 4 the middle estimate is 1.3-fold (0.11 log units) below the measured one; low and high end bracket the measured number.
By their numbers in this assay, from the lowest: compounds 3, 4, 1 and 2 (each within the scatter of the next).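

Amino in place of hydrogen on an aromatic carbon, ortho to a fused ring and two atoms from the ring nitrogen, gives a 1.2-fold higher number from compound 3 to compound 4 (0.08 log units; within the scatter) in this assay. For the compounds shown here, the earlier steps concerned only bromo, so this is the first reading for a group counted with a hydrogen-bond donor and acceptor, and the first for this carbon of the shared core; here too the change stays within the scatter. No measurement at hand speaks to the reason for this result.

Still open, on these data alone, is whether a larger group on this same carbon, such as dimethylamino, methoxy or a carboxylic acid, would also stay within the scatter, and whether amino behaves the same on the carbons that carry bromo in compound 1 and compound 2. Going by these compounds alone, as every step so far lies within the scatter, it also remains open whether any single change on the shared core can move the number beyond it.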